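Amide aryl variation on the shared core

This account rests on a few compounds, and the source may have more. Where it says the series, first, only, none or still open, it means among the compounds named here.

Compound 1 `O=C(CCc1ccccc1)Nc1c(C(O)(C(F)(F)F)C(F)(F)F)ccc2ccccc12` gives 1750 nM in an assay on LtK cells with ATP-sensitive inward rectifier potassium channel 11 (Homo sapiens) as the target; a lower number here means that less compound is needed, a higher number that more compound is needed for the effect. Among the compounds with values here, compound 2 `O=C(Nc1c(C(O)(C(F)(F)F)C(F)(F)F)ccc2ccccc12)c1ccc(F)cc1` gives 70 nM in this assay and holds the lowest of the two numbers measured so far; its nearest neighbour is compound 1. Within the data shown here, the only measured step is a 25-fold lower number from compound 1 to compound 2 (1.40 log units; beyond the scatter), a large one.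

Compound 3 `O=C(Nc1c(C(O)(C(F)(F)F)C(F)(F)F)ccc2ccccc12)c1cc(Cl)cc(Cl)c1` is not yet measured. It differs from compound 2 in this way: 3,5-dichlorophenyl in place of 4-fluorophenyl on a carbonyl carbon. Among the measured compounds shown here, the single measured step touched the same carbonyl carbon, but it exchanged a chain for an aryl ring, whereas the new step exchanges one aryl ring for another, so it gives no direct reading on the present change. Both compound 2 and compound 3 keep the aryl amide. For compound 3 the expectation is therefore a step of a 1.4-fold higher number from compound 2 to compound 3 (0.15 log units; within the scatter) in this assay, not clearly beyond the scatter in either direction, with the wide range reflecting the absence of any aryl-to-aryl comparison. Compound 3 is expected to give 100 nM in this assay, with a range from 30 nM to 350 nM.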

Compound 3, half-maximal effective concentration: 306 nM
Compound 3: middle estimate off by 3.1-fold (0.49 log units), on the low side, and the stated range covers the measured number.
By their numbers in this assay, from the lowest: compound 2; then compound 3; then compound 1.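

In this assay, the aryl ring on the carbonyl carbon is not interchangeable: 3,5-dichlorophenyl in place of 4-fluorophenyl gives a 4.4-fold higher number from compound 2 to compound 3 (0.64 log units; beyond the scatter) and moves the number beyond the scatter, so the identity of the ring matters and not only the presence of an aryl amide. Compound 3 still stands apart from the phenethyl amide, with a 5.7-fold lower number from compound 1 to compound 3 (0.76 log units; beyond the scatter) as a smaller step than the one to compound 2, so both aryl amides shown lie on the lower side of compound 1 while differing clearly from each other. No measurement available here bears on what lies behind the difference between the two rings.

The step from compound 2 to compound 3 changes the halogen, the number of halogens and their placing all at once, and the compounds shown cannot separate these parts. A plain phenyl ring or a phenyl ring with a single chlorine would divide the step, and a ring carrying a methoxy group or a nitrile would show whether anything other than a halogen is tolerated on this amide.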